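Amino for Methoxy on a Shared Nucleoside Core

The source may report more compounds than this note shows. Statements on the series, on what has been measured and on what is new or still open speak of the compounds shown alone.

Measured in a functional assay on HL-60 cells (Homo sapiens) for antiproliferative activity, read by XTT assay, with a stated time of 72 h (on this read-out lower numbers stand for stronger inhibition and higher numbers for weaker inhibition), each value a limit of the assay:
compound 1 `Nc1nc(N)c2c(-c3ccsc3)cn([C@@H]3O[C@H](CO)[C@@H](O)[C@H]3O)c2n1`: > 20000 nM
compound 2 `Nc1nc(N)c2c(-c3ccccc3)cn([C@@H]3O[C@H](CO)[C@@H](O)[C@H]3O)c2n1`: > 15000 nM
compound 3 `COc1nc(N)nc2c1c(-c1ccco1)cn2[C@@H]1O[C@H](CO)[C@@H](O)[C@H]1O`: > 20000 nM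

Compound 3 stands only at a limit, > 20000 nM, and shares it with compound 1 under (the limit of > 20000 nM in this assay, at which 2 of the 3 values shown sit); compound 2 sits at the limit of > 15000 nM in this assay, at which 1 of the 3 values shown sits. Compound 4 `Nc1nc(N)c2c(-c3ccco3)cn([C@@H]3O[C@H](CO)[C@@H](O)[C@H]3O)c2n1` differs from compound 3 by amino in place of methoxy on an aromatic carbon. Within the data shown here, the one measured step, a step that the two limits leave unreadable from compound 1 to compound 2, is unreadable and concerns another position, so no step size bears directly on this change. Every value shown is a limit, so a readable shift in this assay cannot be expected. Compound 4 is therefore expected at about 20000 nM, with a range from 7000 nM to 60000 nM. The expected step is a number no higher from compound 3 to compound 4 (the limit leaves the size open).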

Compound 4, half-maximal inhibitory concentration: > 20000 nM
Compound 4 was reported as a limit (the forecaster's own chance of this, stated with the estimate: 80%); the middle value lies on the limit itself.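

Compound 4 is reported only as a limit, as are compound 1, compound 2 and compound 3, so none of its steps from those compounds can be read. The compounds shown leave open whether amino in place of methoxy, or any exchange of the aromatic group on the shared core, changes activity in this assay.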